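The compounds below may be only part of what the source reports. "The series", "measured", "known", "first", "only" and "open" are said of these compounds alone.

Values in a functional assay on HCT-116 cells (Homo sapiens) for antiproliferative activity, read by MTT assay, with a stated time of 48 h; a higher number here means a weaker inhibitor, a lower number a stronger inhibitor:
compound 1 `N#CC1=C(N)Oc2c(N)cc3nc4ccccc4nc3c2C12C(=O)N(Cc1cnnn1-c1ccccc1Br)c1ccccc12` gives 12400 nM
compound 2 `CCc1cccc(CC)c1-n1nncc1CN1C(=O)C2(C(C#N)=C(N)Oc3c(N)cc4nc5ccccc5nc4c32)c2ccccc21` gives 37600 nM

Among the measured compounds shown here, compound 2 stands highest of the two numbers, with compound 1 its only and nearest neighbour; the single step between them is a 3.0-fold higher number from compound 1 to compound 2 (0.48 log units; beyond the scatter), a modest change. Compound 3 `Cc1cc(C)c(-n2nncc2CN2C(=O)C3(C(C#N)=C(N)Oc4c(N)cc5nc6ccccc6nc5c43)c3ccccc32)c(C)c1` differs from compound 2 by 2,4,6-trimethylphenyl in place of 2,6-diethylphenyl on an aromatic nitrogen. For the measured compounds named here, no measured step exchanges the 2,6-diethylphenyl group for another group on this aromatic nitrogen; the only step in hand compares 2-bromophenyl with 2,6-diethylphenyl and so bears on compound 3 only loosely. Going by the values given here, with no step of its own kind to lean on, the change from compound 2 to compound 3 is expected to stay within the scatter, leaning if anything toward a slightly lower number, and the expected step is a 1.3-fold lower number from compound 2 to compound 3 (0.13 log units; within the scatter). Compound 3 is therefore estimated at 28000 nM, with a range from 11000 nM to 65000 nM.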

Compound 3, half-maximal inhibitory concentration: > 50000 nM
Compound 3 ended at the assay's limit (the forecaster's own chance of this, stated with the estimate: 5%); at least 1.7-fold (0.25 log units) between middle value and limit.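

In this assay compound 3 is read only as a limit of the assay, > 50000 nM, not as a number. On these data alone, the exchange of 2,6-diethylphenyl for 2,4,6-trimethylphenyl gives an at least 1.3-fold higher number from compound 2 to compound 3 (0.12 log units; that floor lies within the scatter), so this floor does not separate the two alkyl-substituted phenyl groups, and their true gap remains unknown. The exchange of 2-bromophenyl for 2,4,6-trimethylphenyl gives an at least 4.0-fold higher number from compound 1 to compound 3 (0.60 log units; beyond the scatter), so a second alkyl-substituted phenyl group on this aromatic nitrogen now stands beyond the scatter from compound 1, and none of the three compounds goes against that pattern.

Compound 3 lacks the bromine of compound 1 and carries alkyl groups instead. The data do not tell these two changes apart. Also open, as far as these compounds go, is how a phenyl group carrying an amine or a carboxylic acid would read at this position.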